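The compounds below may be only part of what the source reports. "The series", "measured", "known", "first", "only" and "open" are said of these compounds alone.

In a functional assay on MCF7 cells (Homo sapiens) for antiproliferative activity, read by MTT assay, with a stated time of 24 h (on this read-out lower numbers stand for stronger inhibition and higher numbers for weaker inhibition), compound 1 `COc1ccc(-c2noc(C3CCNCC3)n2)cc1OC1CCCC1` gives 3880 nM. Compound 2 `COc1ccc(-c2noc(-c3cccnc3)n2)cc1OC1CCCC1` carries pyridin-3-yl in place of piperidin-4-yl on an aromatic carbon of the shared core. Compound 2 reads > 1000000 nM, which is a limit of the assay and not a number. Compound 2 therefore stands at the limit of > 1000000 nM in this assay, at which 1 of the 2 values shown sits. Going by the values given here, the only measured step is large: an at least 250-fold higher number from compound 1 to compound 2 (2.41 log units; beyond the scatter). It shows that the group at this place can matter a great deal.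

Compound 3 `COc1ccc(-c2noc(-c3ccc(O)cc3)n2)cc1OC1CCCC1` changes that same place again: 4-hydroxyphenyl in place of pyridin-3-yl on an aromatic carbon. In words, 4-hydroxyphenyl replaces pyridin-3-yl, so the six-membered aromatic ring stays but is now of carbon only. Compound 3 does not bring back the piperidin-4-yl of compound 1, and the measured step of an at least 250-fold higher number from compound 1 to compound 2 (2.41 log units; beyond the scatter) is the one sign that losing this group costs much. A return to the level of compound 1 therefore seems unlikely, and only a modest move towards a lower number is expected. The expected step is an at least 5.0-fold lower number from compound 2 to compound 3 (0.69 log units; beyond the scatter). Compound 3 is estimated at 200000 nM, with an expected range of 20000 nM to 1000000 nM.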

Compound 3, half-maximal inhibitory concentration: 390 nM
The estimate for compound 3 lay 510-fold (2.71 log units) above the measured number; measured number below the stated range.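

In this assay, replacing pyridin-3-yl with 4-hydroxyphenyl gives an at least 2500-fold lower number from compound 2 to compound 3 (3.40 log units; beyond the scatter), so the mere presence of a six-membered aromatic ring at this place does not settle the outcome: the kind of ring and what it carries make a very large difference. The saturated, nitrogen-containing piperidin-4-yl of compound 1 is also not required for activity, since 4-hydroxyphenyl gives a 9.9-fold lower number from compound 1 to compound 3 (1.00 log units; beyond the scatter), leaving compound 3 with the lowest number of the three compounds shown. The first of these steps has no fixed size because compound 2 reaches only a limit of the assay, not a number: the limit of > 1000000 nM in this assay, at which 1 of the 3 values shown sits.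

Compound 3 differs from compound 2 in two ways at once, with no ring nitrogen and a new hydroxyl group, so these compounds cannot show which of the two changes accounts for the gain. A plain phenyl ring would help to separate them, while 3-hydroxyphenyl, or a methoxy group or an amine in place of the hydroxyl, would test how much depends on that group and where it sits on the ring.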